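A few compounds are considered here, and "the series" means these few. Any claim that something is new, unique, unknown or untested is made for them only; others in the source may bear on it.

Within the data shown here, in a functional assay on M21 cells (Homo sapiens) for antiproliferative activity, read by sulforhodamine B assay, with a stated time of 48 h (a lower number here means a stronger inhibitor, a higher number a weaker inhibitor), compound 1 `Cc1cccc(NS(=O)(=O)c2ccc(N3CCNC3=O)cc2)c1` gives 69 nM and stands lowest of the three numbers measured so far. Compound 2 `O=C1NCCN1c1ccc(S(=O)(=O)Nc2ccc(I)cc2)cc1` gives 260 nM and compound 3 `CCc1ccc(NS(=O)(=O)c2ccc(N3CCNC3=O)cc2)cc1` gives 480 nM in this assay. Compound 4 `COc1ccc(NS(=O)(=O)c2ccc(N3CCNC3=O)cc2)cc1` has not yet been measured; it differs from compound 1 in one place: 4-methoxyphenyl in place of 3-methylphenyl on a sulfonamide nitrogen. Among the measured compounds shown here, two measured steps bear on this change, since each also replaced 3-methylphenyl on a sulfonamide nitrogen with a different aryl group: a 3.8-fold higher number from compound 1 to compound 2 (0.58 log units; beyond the scatter) and a 7.0-fold higher number from compound 1 to compound 3 (0.84 log units; beyond the scatter). Both gave weaker inhibitors, beyond the scatter. A modest step in the same direction is therefore expected for the change from compound 1 to compound 4 in this assay, namely a 4.3-fold higher number from compound 1 to compound 4 (0.64 log units; beyond the scatter). Compound 4 is estimated at 300 nM with an expected range from 100 nM to 900 nM.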

Compound 4, half-maximal inhibitory concentration: 580 nM
Beside the measured number, compound 4's estimate is 1.9-fold (0.29 log units) below it; measured number inside the range.
By their numbers in this assay, from the lowest: compound 1; then compounds 2, 3 and 4 (each within the scatter of the next, the first and the last beyond it).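

With 4-methoxyphenyl on the sulfonamide nitrogen in this assay, the result is an 8.4-fold higher number from compound 1 to compound 4 (0.92 log units; beyond the scatter), so all three 4-substituted phenyl groups shown give weaker inhibitors than 3-methylphenyl. Methoxy and ethyl cannot be told apart, with a 1.2-fold higher number from compound 3 to compound 4 (0.08 log units; within the scatter), whereas replacing iodo with methoxy gives a 2.2-fold higher number from compound 2 to compound 4 (0.35 log units; beyond the scatter), just beyond the scatter. No measurement at hand explains these differences.

Going by these compounds, it remains open whether the advantage of compound 1 belongs to the methyl group or to where it sits on the ring. A 4-methylphenyl or 3-methoxyphenyl group would separate those two possibilities.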